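Furan-2-yl in place of hydrogen on a shared core

The compounds below may be only part of what the source reports. "The series", "measured", "known", "first", "only" and "open" are said of these compounds alone.

Three compounds built on a shared core that carries a propyl group have been measured in an assay on CHO cells for displacement of a labelled ligand from adenosine receptor A1 (Homo sapiens); a higher number here means a weaker inhibitor, a lower number a stronger inhibitor. Compound 1 `CCCn1c(Br)nc2c(N)nc(NCc3ccccc3)nc21` gives 358 nM. Compound 2 `CCCn1cnc2c(NCc3ccccc3)ncnc21` gives 42800 nM, the highest of the three numbers, so it is the weakest inhibitor of the set. Compound 3 `CCCn1cnc2c(NCCCc3ccccc3)ncnc21` gives 18600 nM, the number nearest to that of compound 2, and the gap from compound 2 to compound 3 lies beyond the usual scatter, as does the much larger gap from compound 2 down to compound 1.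

Compound 4 `CCCn1c(-c2ccco2)nc2c(NCc3ccccc3)ncnc21` has not yet been measured. It differs from compound 2 in one place: furan-2-yl in place of hydrogen on an aromatic carbon. For the measured compounds named here, no measured pair in this set changes only that spot, so the data give no direct step for it. Compound 1 differs from compound 2 in several places at once, and its far lower number cannot be traced to any single one of them.

The expectation is nonetheless that compound 4 will be a stronger inhibitor than compound 2, with an estimated step of a 14-fold lower number from compound 2 to compound 4 (1.15 log units; beyond the scatter). The estimate for compound 4 is 3000 nM, expected to fall within a range from 500 nM to 20000 nM.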

Compound 4, inhibition constant: 546 nM
For compound 4 the middle estimate is 5.5-fold (0.74 log units) above the measured one, within the range that was stated.
By their numbers in this assay, from the lowest: compounds 1 and 4 (each within the scatter of the next); then compound 3; then compound 2.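

In this assay, furan-2-yl in place of hydrogen on the aromatic carbon between two ring nitrogen atoms gives a 78-fold lower number from compound 2 to compound 4 (1.89 log units; beyond the scatter) and this large step lies beyond the scatter. For the compounds shown here, it is the only step in the set that changes one place alone, so it is the first direct sign that this position, next to the ring atom that bears a propyl group, matters for the number in this assay: adding a five-membered aromatic ring with 1 hetero atom here has a strong effect with the rest of the molecule unchanged. Nothing in the data shown explains the size of this step.

Open, from the compounds shown here alone, is whether this step belongs to furan-2-yl itself or whether a methyl group, a phenyl ring or an amine on the same carbon would give a similar one, since compound 1 carries bromine there but differs from compound 2 in several places at once. Also open, going by these compounds, is whether furan-2-yl would give a step of similar size on compound 3, which has the longer chain.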